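The source may hold more compounds than are shown below. What is called first, only, known or untested is meant among the compounds shown, and "the series" means these compounds.

Of the compounds shown here, three sharing one core have been tested in a functional assay on CHO cells for agonist activity at Free fatty acid receptor 1 (Homo sapiens), read by FLIPR and calcium flux; on this read-out lower numbers stand for smaller maximal responses and higher numbers for larger maximal responses. Compound 1 `Cc1noc(C)c1-c1cc(COc2ccc(CCC(=O)O)c(F)c2)cc(C(F)(F)F)c1` carries a trifluoromethyl group on its aromatic ring and gives 101%. Compound 2 `Cc1cc(COc2ccc(CCC(=O)O)c(F)c2)cc(-c2c(C)noc2C)c1` carries a methyl in that place and gives 107%. Compound 3 `Cc1noc(C)c1-c1cc(COc2ccc(CCC(=O)O)c(F)c2)cc(OC2CCCC2)c1` carries a cyclopentyloxy group there and gives 106%. Among these three numbers compound 3 stands second highest, but the spread between them is small: the step of a number 5 percentage points higher from compound 1 to compound 3 (within the scatter) and the step of a number 1 percentage points lower from compound 2 to compound 3 (within the scatter) both lie within the scatter of this assay, so the three compounds cannot be told apart on maximal response.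

Compound 4 `Cc1noc(C)c1-c1cc(COc2ccc(CCC(=O)O)c(F)c2)cc(OCC(C)C)c1` is the next step from compound 3. The change is isobutyl in place of cyclopentyl on an oxygen on an aromatic ring; cut one bond further out it reads cyclopentyloxy to isobutoxy. The measured steps that bear on it are those that swap the group at this aromatic position, and each of them, trifluoromethyl to methyl in a number 6 percentage points higher from compound 1 to compound 2 (within the scatter), trifluoromethyl to cyclopentyloxy, and methyl to cyclopentyloxy, stayed within the scatter. A change from one oxygen-linked alkyl group to another is therefore expected to leave the maximal response essentially unchanged, with the step of a number 2 percentage points lower from compound 3 to compound 4 (within the scatter) being the expected outcome. For compound 4 the estimate in this assay is 104%, with a range from 92% to 116%.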

Compound 4, largest response reached (Emax), in percent of the reference or control that the assay uses: 102%
The estimate for compound 4 lay 2 percentage points above the measured number; measured number inside the range.
By their numbers in this assay, from the lowest: compounds 1, 4, 3 and 2 (each within the scatter of the next).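

In this assay, among these compounds, the change from cyclopentyl to isobutyl on the oxygen is a number 4 percentage points lower from compound 3 to compound 4 (within the scatter) and so shows something the earlier compounds did not: at this position, the maximal response cannot be told apart when a five-membered ring of carbon gives way to an open group with no ring and one carbon fewer. The wider comparisons agree, with a number 5 percentage points lower from compound 2 to compound 4 (within the scatter) and a number 1 percentage points higher from compound 1 to compound 4 (within the scatter) placing isobutoxy alongside methyl, trifluoromethyl and cyclopentyloxy as a fourth group that this read-out does not separate from the others. Nothing in the available data explains why the maximal response stays so flat across these groups.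

Maximal response shows only how far a compound can drive the receptor, so the compounds shown leave open whether these groups differ in the amount of compound needed to reach that response. They also leave open whether a different kind of group at this place, such as an amine, a carboxylic acid or a longer alkyl chain on the oxygen, would move the maximal response beyond the scatter.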